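The source may report more compounds than this note shows. Statements on the series, on what has been measured and on what is new or still open speak of the compounds shown alone.

Measured so far:

Compound 1 `C=CCN(C)C(=O)c1ccc(C(CC)(CC)c2ccc(OCCC(O)(CC)CC)c(C)c2)n1CC`: > 50000 nM
Compound 2 `C#CC(C)OC(=O)c1ccc(C(CC)(CC)c2ccc(OCCC(O)(CC)CC)c(C)c2)n1CC`: > 50000 nM
Compound 3 `C#CCCOC(=O)c1ccc(C(CC)(CC)c2ccc(OCCC(O)(CC)CC)c(C)c2)n1CC`: > 50000 nM

In a functional assay on MCF7 cells (Homo sapiens) for antiproliferative activity, read by MTT assay, with a stated time of 48 h (a lower number here means a stronger inhibitor, a higher number a weaker inhibitor), compound 1 gives > 50000 nM, which is a limit of the assay and not a number. Compound 2 gives > 50000 nM, likewise a limit. Compound 3 gives > 50000 nM, again a limit. Because (the limit of > 50000 nM in this assay, at which 3 of the 3 values shown sit), no step among these three can be read: a step that the two limits leave unreadable from compound 1 to compound 2, a step that the two limits leave unreadable from compound 1 to compound 3 and a step that the two limits leave unreadable from compound 2 to compound 3 all remain of unknown size. Compound 1 therefore stands only at the limit, with nothing to rank it against compound 2 or compound 3.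

The next compound, compound 4 `CCn1c(C(=O)N(C)CC(=O)O)ccc1C(CC)(CC)c1ccc(OCCC(O)(CC)CC)c(C)c1`, differs from compound 1 by carboxy in place of vinyl on a saturated chain carbon bound to an amide-type nitrogen. The two measured steps that touch the same carbonyl substituent, from compound 1 to compound 2 and from compound 1 to compound 3, both start and end at the limit, so they give no readable size and no direction. Nothing in the series shows any change in this assay leaving the limit. Compound 4 is therefore expected to sit at the limit as well, with the step that the limit leaves unreadable from compound 1 to compound 4 expected to be unreadable. Compound 4 is estimated at 80000 nM, with a range from 30000 nM to 300000 nM, most likely reported only as a limit.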

Compound 4, half-maximal inhibitory concentration: 79 nM
Compound 4: middle estimate off by 1000-fold (3.01 log units), on the high side, and the stated range ends above it.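

In this assay this carbonyl substituent proves able to move the series, and compound 4 gives 79 nM as the first readable value, with carboxy in place of vinyl on a saturated chain carbon bound to an amide-type nitrogen (an at least 630-fold lower number from compound 1 to compound 4 (2.80 log units; beyond the scatter)). The same drop appears when (carboxymethyl)(methyl)amino replaces either ester group on the carbonyl carbon, (but-3-yn-1-yl)oxy (an at least 630-fold lower number from compound 3 to compound 4 (2.80 log units; beyond the scatter)) or (1-methylprop-2-yn-1-yl)oxy (an at least 630-fold lower number from compound 2 to compound 4 (2.80 log units; beyond the scatter)), so compound 4 separates from all three other compounds, whose steps among themselves cannot be read. These sizes are lower bounds only, and the true gaps may be larger, because each starting compound carries a limit and not a number: the limit of > 50000 nM in this assay, at which 3 of the 4 values shown sit.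

Going by these compounds, whether the free carboxy itself is needed stays open, since a methyl ester or a primary amide on the same chain carbon would separate the acid from the rest of the carboxymethyl group. Also open, on these data alone, is how the value responds to chain length, as with a carboxyethyl group, and to a hydrogen in place of the methyl on the amide-type nitrogen.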